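Acetyl to benzoyl: a small shift expected

The compounds below may be only part of what the source reports. "The series", "measured", "known", "first", "only" and "open" are said of these compounds alone.

compound 1 `COc1ccc(S(=O)(=O)N2CCc3cccc(NC(=O)c4cccs4)c32)cc1` gives 49 nM
compound 2 `COc1ccc(S(=O)(=O)N2CCc3cccc(NC(=O)c4ccncc4)c32)cc1` gives 9.4 nM
compound 3 `COc1ccc(S(=O)(=O)N2CCc3cccc(NC(C)=O)c32)cc1` gives 75 nM

In a functional assay on NCI-H460 cells (Homo sapiens) for cytotoxicity (a higher number here means a weaker inhibitor, a lower number a stronger inhibitor), compound 3 at 75 nM sits level with compound 1 within the scatter, and only compound 2 stands clearly apart from it. Compound 4 `COc1ccc(S(=O)(=O)N2CCc3cccc(NC(=O)c4ccccc4)c32)cc1` keeps the shared core and changes one group: phenyl in place of methyl on a carbonyl carbon puts phenyl in place of methyl on a carbonyl carbon. Two measured steps make the same kind of swap at that place, though they run from a ring compound to the methyl one. The first is a 1.5-fold higher number from compound 1 to compound 3 (0.18 log units; within the scatter) and stays within the scatter. The second is an 8.0-fold higher number from compound 2 to compound 3 (0.90 log units; beyond the scatter) and is modest. Replacing methyl with a ring has therefore meant anything from no clear change to a modest drop in the number, and phenyl lies untested. A small drop is expected here, with the estimated step being a 2.0-fold lower number from compound 3 to compound 4 (0.30 log units; within the scatter) in the direction of a stronger inhibitor. The estimate for compound 4 is 38 nM with an expected range of 12 nM to 110 nM around it.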

Compound 4, half-maximal inhibitory concentration: 257 nM
The estimate for compound 4 lay 6.8-fold (0.83 log units) below the measured number, outside the stated range (above it).
By their numbers in this assay, from the lowest: compound 2; then compounds 1 and 3 (each within the scatter of the next); then compound 4.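

In this assay, putting a ring on this carbonyl carbon does not by itself lower the number: phenyl in place of methyl gives a 3.4-fold higher number from compound 3 to compound 4 (0.53 log units; beyond the scatter), the opposite direction to the step pyridin-4-yl made against methyl. Which ring stands there clearly matters, as swapping the other two rings for phenyl gives a 27-fold higher number from compound 2 to compound 4 (1.44 log units; beyond the scatter) and a 5.2-fold higher number from compound 1 to compound 4 (0.72 log units; beyond the scatter), leaving compound 4 the weakest of the four. Nothing measured here explains why phenyl parts from the other two rings.

Going by these compounds, it remains open whether a saturated ring such as cyclohexyl or a longer chain such as butyl on this carbonyl carbon would fall nearer to compound 3 or to compound 4. Also open, on these data alone, is whether an amine on the phenyl ring would bring the number back towards that of compound 2.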